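Benzylsulfanyl on the Shared Core: Expected Cytotoxicity

A few compounds are considered here, and "the series" means these few. Any claim that something is new, unique, unknown or untested is made for them only; others in the source may bear on it.

Compound 1 `Nc1nc(NC2CC2)c2ncn(/C=C3/CC3(CO)CO)c2n1`: > 300000 nM (a limit)
Compound 2 `CCCSc1nc(N)nc2c1ncn2/C=C1/CC1(CO)CO`: > 300000 nM (a limit)
Compound 3 `Nc1nc(NC2CCCC2)c2ncn(/C=C3/CC3(CO)CO)c2n1`: > 300000 nM (a limit)

All three compounds were tested in an ADME assay on HFF cells (Homo sapiens) for cytotoxicity, with a stated time of 8 days; on this read-out lower numbers stand for higher toxicity in this test and higher numbers for lower toxicity in this test. In this assay compound 1 gives > 300000 nM, which is a limit of the assay and not a number. In this assay compound 2 gives > 300000 nM, again a limit. In this assay compound 3 gives > 300000 nM, also a limit. Because every value sits at the limit of > 300000 nM in this assay, at which 3 of the 3 values shown sit, none of the steps between them can be sized: a step that the two limits leave unreadable from compound 1 to compound 2, a step that the two limits leave unreadable from compound 1 to compound 3 and a step that the two limits leave unreadable from compound 2 to compound 3 remain unreadable.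

Compound 4 `Nc1nc(SCc2ccccc2)c2ncn(/C=C3/CC3(CO)CO)c2n1` is not yet measured. It differs from compound 1 in one place: benzylsulfanyl in place of cyclopropylamino on an aromatic carbon. Among the measured compounds shown here, no measured step matches this change, and the steps that touch the same aromatic carbon are all hidden by the limit. For the measured compounds named here, the only guidance is that three different groups at that position and at the ring nitrogen all leave the cells untouched up to the limit.

Compound 4 is therefore expected to behave like compound 1, with no step beyond the scatter, so a number no higher from compound 1 to compound 4 (the limit leaves the size open) is the expected outcome. The estimate for compound 4 in this assay is 300000 nM, expected to fall between 100000 nM and 1000000 nM, most likely reported again only as a limit.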

Compound 4, half-maximal cytotoxic concentration: > 300000 nM
Compound 4 gave a limit, no number (the forecaster's own chance of this, stated with the estimate: 70%); the middle value sits exactly at the limit.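

In this assay compound 4 gives > 300000 nM, which is a limit of the assay and not a number. None of the steps among compound 1, compound 2, compound 3 and compound 4 can be read: the limit of > 300000 nM in this assay, at which 4 of the 4 values shown sit.

The compounds shown leave open whether these groups differ at all in their toxicity to these cells, as none of the four gives a number.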